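A few compounds are considered here, and "the series" means these few. Any claim that something is new, unique, unknown or untested is made for them only; others in the source may bear on it.

Measured so far:
- compound 1 `O=C(/C(=C\c1ccc(O)cc1)SCc1ccc(Cl)cc1)c1ccc(Br)cc1` — 10000 nM
- compound 2 `O=C(/C(=C\c1ccc(O)cc1)SCc1ccc(F)cc1)c1ccc(Cl)cc1` — 25000 nM
- compound 3 `Cc1ccc(CS/C(=C/c2ccc(O)cc2)C(=O)c2ccc(Cl)cc2)cc1` — 10000 nM

All three were read in a functional assay on DU-145 cells (Homo sapiens) for inhibition, read by trypan blue exclusion, with a stated time of 96 h; on this read-out lower numbers stand for stronger inhibition of growth and higher numbers for weaker inhibition of growth. Going by the values given here, compound 3 stands level with compound 1 at the digits printed, the two together giving the lowest numbers of the three; compound 2 sits furthest from it, the step of a 2.5-fold lower number from compound 2 to compound 3 (0.40 log units; beyond the scatter) being the only one between neighbours that lies beyond the scatter.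

Compound 4 `O=C(/C(=C\c1ccc(O)cc1)SCc1ccc(Cl)cc1)c1ccc(Cl)cc1` is not yet measured. Relative to compound 3 the change is chloro in place of methyl on an aromatic carbon. Among the compounds with values here, no measured step covers chloro in place of methyl on that ring directly. Within the data shown here, the one step that bears on the same benzyl ring, a 2.5-fold lower number from compound 2 to compound 3 (0.40 log units; beyond the scatter), was modest. The (4-chlorobenzyl)sulfanyl group of compound 4 is already present in compound 1, on a core differing only elsewhere, and compound 1 gives 10000 nM, the same number as compound 3. On that basis the step of no change at the digits printed from compound 3 to compound 4 (within the scatter) is expected to stay within the scatter, with no direction favoured. Compound 4 is therefore estimated at 10000 nM, with a range of 4000 nM to 25000 nM.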

Compound 4, concentration for 50% growth inhibition: 10000 nM
For compound 4 middle estimate and measured number coincide at the digits printed, within the range that was stated.
By their numbers in this assay, from the lowest: compounds 1, 3 and 4 (each within the scatter of the next); then compound 2.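

In this assay, the change from 4-methylbenzyl to 4-chlorobenzyl gives (no change at the digits printed from compound 3 to compound 4 (within the scatter)), so chloro and methyl cannot be told apart at this position. Fluoro now stands apart from both, as chloro in place of fluoro gives (a 2.5-fold lower number from compound 2 to compound 4 (0.40 log units; beyond the scatter)), a modest step that matches the one already seen for methyl in place of fluoro. Chloro in place of bromo on an aromatic carbon elsewhere in the molecule gives (no change at the digits printed from compound 1 to compound 4 (within the scatter)), so that halogen exchange also leaves the number in place.

Nothing at hand bears on the cause of these steps. Open, as far as these compounds go, is whether a methoxy group, an amine or a carboxylic acid on the benzyl ring would move the number beyond the span of these halogen and methyl compounds.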